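Replacing chloro with hydrogen in compound 2

The compounds below may be only part of what the source reports. "The series", "measured", "known", "first", "only" and "open" are said of these compounds alone.

Measured in an ADME assay on J774 cells (Mus musculus) for cytotoxicity, read by fluorescence and resazurin assay, with a stated time of 24 h; a lower number here means that less compound is tolerated, a higher number that more compound is tolerated:
- compound 1 `Cc1cc2cc(NS(=O)(=O)c3ccc([N+](=O)[O-])cc3)ccc2[nH]1`: 132000 nM
- compound 2 `Cc1cc2cc(NS(=O)(=O)c3ccc(Cl)cc3)ccc2[nH]1`: 195000 nM

On these numbers, the two measured compounds cannot be told apart, and compound 2 stands level with the other within the scatter. For the measured compounds named here, their only step is a 1.5-fold higher number from compound 1 to compound 2 (0.17 log units; within the scatter), with chloro in place of nitro on an aromatic carbon. Compound 3 `Cc1cc2cc(NS(=O)(=O)c3ccccc3)ccc2[nH]1` differs from compound 2 by hydrogen in place of chloro on an aromatic carbon. The measured step of a 1.5-fold higher number from compound 1 to compound 2 (0.17 log units; within the scatter) changed the group on that same carbon, so no step beyond the scatter is expected in this assay. For compound 3 the expected value is 170000 nM, with an estimated range of 90000 nM to 300000 nM. This estimate amounts to an expected 1.1-fold lower number from compound 2 to compound 3 (0.06 log units; within the scatter).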

Compound 3, half-maximal cytotoxic concentration: >= 300000 nM
Compound 3: no number, only a limit (the forecaster's own chance of this, stated with the estimate: 20%); at least 1.7-fold (0.24 log units) between middle value and limit.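

Compound 3 is read only as a limit in this assay: the limit of >= 300000 nM in this assay, at which 1 of the 3 values shown sits.

Hydrogen in place of nitro gives the first step at this position that lies beyond the scatter, an at least 2.2-fold higher number from compound 1 to compound 3 (0.35 log units; beyond the scatter). Hydrogen in place of chloro gives an at least 1.5-fold higher number from compound 2 to compound 3 (0.18 log units; that floor lies within the scatter), so that floor alone does not separate the two compounds.

From the compounds shown here alone, the true size of both steps remains open, since only a floor is known for each. Also open, going by these compounds, is how this assay would read with an amine, a methoxy group or a carboxylic acid on that same carbon.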